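From chloro to cyano at an assay limit

The source may hold more compounds than are shown below. What is called first, only, known or untested is meant among the compounds shown, and "the series" means these compounds.

In a functional assay on the whole organism for positive allosteric modulation, with Mus musculus as the target (a lower number here means that less compound is needed, a higher number that more compound is needed for the effect), compound 1 (`CCC(=O)N(c1ccc(Cl)cc1)C1CCCC1N(C)C`) gives > 50 mg/kg, which is a limit of the assay and not a number. Two relatives do reach a number. Compound 2 (`CCC(=O)N(c1ccc(Cl)c(C)c1)C1CCCC1N(C)C`), with a methyl in place of a hydrogen on an aromatic carbon, gives 10 mg/kg. Compound 3 (`CCC(=O)N(c1cc(Cl)cc(Cl)c1)C1CCCC1N(C)C`), with two chloro groups, gives 30 mg/kg. Among the compounds with values here, the one measured step is an at least 5.0-fold lower number from compound 1 to compound 2 (0.69 log units; beyond the scatter), which lies beyond the scatter, but it leaves the chloro group in place.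

Compound 4 (`CCC(=O)N(c1ccc(C#N)cc1)C1CCCC1N(C)C`) changes something else: cyano in place of chloro on an aromatic carbon. This puts cyano in place of chloro on an aromatic carbon, para to a large group. Within the data shown here, no measured compound here carries a cyano, and compound 4 lacks the extra ring group found in compounds 2 and 3. No clear gain is therefore expected in this assay, and the estimated change is only a step that the limit leaves unreadable from compound 1 to compound 4. The assay may well report only a limit again. For compound 4, the expected value is 60 mg/kg, with an estimated range from 20 mg/kg to 150 mg/kg.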

Compound 4, dose for half-maximal effect: > 50 mg/kg
Compound 4 gave a limit, no number; the forecaster's own chance of this, stated with the estimate: 60%; the middle value does not contradict the limit.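

Compound 1 and compound 4 both stop at a limit of the assay rather than a number, so no step can be read between them: the limit of > 50 mg/kg in this assay, at which 2 of the 4 values shown sit.

The compounds shown leave open how far, in this assay, cyano in place of chloro changes the dose needed.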